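Swapping 1-benzofuran-2-yl for ethynyl at the assay limit

The compounds below may be only part of what the source reports. "The series", "measured", "known", "first", "only" and "open" are said of these compounds alone.

Compound 1 `CNc1ncnc2c1c(-c1ccco1)cn2[C@@H]1O[C@H](CO)[C@@H](O)[C@H]1O`: 440 nM
Compound 2 `CNc1ncnc2c1c(-c1cc3ccccc3o1)cn2[C@@H]1O[C@H](CO)[C@@H](O)[C@H]1O`: > 20000 nM, a limit

Both results come from a functional assay on HCT-116 cells (Homo sapiens), read by MTT assay, with a stated time of 72 h; on this read-out higher numbers stand for weaker inhibition and lower numbers for stronger inhibition. Compound 2 gives only a limit and not a number, and it stands at the limit of > 20000 nM in this assay, at which 1 of the 2 values shown sits.

Compound 3 `C#Cc1cn([C@@H]2O[C@H](CO)[C@@H](O)[C@H]2O)c2ncnc(NC)c12` has not yet been measured. It carries ethynyl in place of 1-benzofuran-2-yl on an aromatic carbon.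

Within the data shown here, one measured step bears on this change. Putting 1-benzofuran-2-yl in place of furan-2-yl gave an at least 45-fold higher number from compound 1 to compound 2 (1.65 log units; beyond the scatter), a large step beyond the scatter. Compound 3 no longer has the group that came with that step, so a large step towards a lower number, meaning stronger inhibition, is expected in this assay. Among the measured compounds shown here, no measured compound other than compound 3 carries ethynyl, so the expectation is loose.

The estimated step is an at least 66-fold lower number from compound 2 to compound 3 (1.82 log units; beyond the scatter). For compound 3 the expected value is 300 nM, with an estimated range from 30 nM to 4000 nM.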

Compound 3, half-maximal inhibitory concentration: > 20000 nM
Compound 3: only a limit was reported; the forecaster's own chance of this, stated with the estimate: 10%; middle value at least 66-fold (1.82 log units) from the limit.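

In this assay, shrinking the 1-benzofuran-2-yl group to ethynyl, which has no ring, does not bring back a measurable value: compound 3 gives > 20000 nM, a limit of the assay. Putting ethynyl in place of furan-2-yl on this aromatic carbon gives an at least 45-fold higher number from compound 1 to compound 3 (1.65 log units; beyond the scatter), so a much smaller group than 1-benzofuran-2-yl can also leave the compound without a measurable value. The step between compound 2 and compound 3 cannot be read, since both results are limits, and they cannot be ranked against each other: the limit of > 20000 nM in this assay, at which 2 of the 3 values shown sit.

Among these compounds, only compound 1, with furan-2-yl, gives a number rather than a limit. On these data alone, whether this position accepts any other group remains open, for example thiophen-2-yl, phenyl or an aminomethyl group.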